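Replacing dimethylamino with a phenylpiperidine on the pyridine amine

This account rests on a few compounds, and the source may have more. Where it says the series, first, only, none or still open, it means among the compounds named here.

Measured compounds:
compound 1 `CC(C(=O)NCc1ccc(C(F)(F)F)nc1N(C)C)c1ccc(NS(C)(=O)=O)c(F)c1` with 19.1 nM
compound 2 `C[C@H](C(=O)NCc1ccc(C(F)(F)F)nc1N1CC[C@@H](OCc2ccccc2)C1)c1ccc(NS(C)(=O)=O)c(F)c1` with 1.4 nM
compound 3 `C[C@H](C(=O)NCc1ccc(C(F)(F)F)nc1N1CC[C@@H](N(C)C)C1)c1ccc(NS(C)(=O)=O)c(F)c1` with 101 nM

In a functional assay on CHO-K1 cells for antagonist activity at transient receptor potential cation channel subfamily V member 1 (Homo sapiens), read by FLIPR (on this read-out higher numbers stand for weaker inhibition and lower numbers for stronger inhibition), compound 1 stands second highest of the three numbers, above compound 2 and below compound 3. The unmeasured compound 4 `CC(C(=O)NCc1ccc(C(F)(F)F)nc1N1CCC(c2ccccc2)CC1)c1ccc(NS(C)(=O)=O)c(F)c1` differs from compound 1 by 4-phenylpiperidin-1-yl in place of dimethylamino on an aromatic carbon. Among the measured compounds shown here, the one measured step that bears on it is a 72-fold higher number from compound 2 to compound 3 (1.86 log units; beyond the scatter), a large weakening when a bulky aryl-bearing group on the saturated ring gives way to dimethylamino. Compound 4 carries the reverse kind of change on the aromatic carbon itself, so a move toward stronger inhibition is expected, though compound 4 lacks defined stereochemistry. Compound 4 is therefore estimated at 5 nM, with a range from 1.5 nM to 20 nM, meaning an expected 3.8-fold lower number from compound 1 to compound 4 (0.58 log units; beyond the scatter).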

Compound 4, inhibition constant: 0.6 nM
The estimate for compound 4 lay 8.3-fold (0.92 log units) above the measured number; the measured number lies below the stated range.
By their numbers in this assay, from the lowest: compound 4; then compound 2; then compound 1; then compound 3.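

In this assay the step of a 32-fold lower number from compound 1 to compound 4 (1.50 log units; beyond the scatter) shows that the aromatic carbon next to the ring nitrogen accepts a far larger group than dimethylamino, and that 4-phenylpiperidin-1-yl there gives stronger inhibition. The earlier step lay on a saturated ring carbon, whereas this one changes the group on the aromatic carbon itself. The compounds shown do not separate the share of the phenyl ring from that of the piperidine, which a plain piperidin-1-yl would help to settle. No measurement shown explains the size of this step.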